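Adding a Second Chloro to a Weakly Cytotoxic Core

The compounds below may be only part of what the source reports. "The series", "measured", "known", "first", "only" and "open" are said of these compounds alone.

Compound 1 `ClCc1ccccc1Cn1cnc2ncnc(Cl)c21` was tested in a functional assay on IGROV-1 cells (Homo sapiens) for cytotoxicity, read by sulforhodamine B assay, with a stated time of 48 h; on this read-out lower numbers stand for higher toxicity in this test and higher numbers for lower toxicity in this test. In this assay compound 1 gives > 100000 nM, which is a limit of the test rather than a measured number. Going by the values given here, the only other value shown comes from a related compound, compound 2 `ClCc1ccc(Cn2cnc3c(Cl)nc(Cl)nc32)cc1`, and in this assay compound 2 gives 60300 nM. Among the compounds with values here, with compound 1 sitting at the limit (the limit of > 100000 nM in this assay, at which 1 of the 2 values shown sits), no step between measured compounds can be drawn, and the pair gives no guide to size. Compound 3 `ClCc1ccccc1Cn1cnc2nc(Cl)nc(Cl)c21` differs from compound 1 by chloro in place of hydrogen on an aromatic carbon, a chloro in place of hydrogen on an aromatic carbon between two ring nitrogen atoms. A modest gain in toxicity, or none beyond the usual scatter, both remain plausible for this step. Compound 3 is expected to give 70000 nM, within 25000 nM to 200000 nM, which means an estimated step of an at least 1.4-fold lower number from compound 1 to compound 3 (0.15 log units; that floor lies within the scatter).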

Compound 3, concentration lethal to 50% of the cells: 9540 nM
Estimate against measurement, compound 3: 7.3-fold (0.87 log units) above; measured number below the stated range.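

In this assay, chloro in place of hydrogen on an aromatic carbon between two ring nitrogen atoms brings an at least 10-fold lower number from compound 1 to compound 3 (1.02 log units; beyond the scatter), the first size that can be read for any change to this core. Compound 1 stands at a limit of the test, so this size is only a floor: the limit of > 100000 nM in this assay, at which 1 of the 3 values shown sits. With this one added chlorine atom, compound 3 gives 9540 nM, a measured number rather than a limit, so this position can clearly change the read-out.

The compounds shown leave open whether another group at this position, such as an amine or a methoxy group, would bring a similar step. They also cannot tell why the chloro has this effect, or whether it would hold in other cell lines.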